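Moving the methoxy group on a hydroxamic acid inhibitor

This account rests on a few compounds, and the source may have more. Where it says the series, first, only, none or still open, it means among the compounds named here.

Compound 1, `O=C(/C=C/c1cccc(S(=O)(=O)N2CCN(c3ccccn3)CC2)c1)NO`: in an assay for inhibition of histone deacetylase 9 (Homo sapiens), read by fluorescence, with a stated time of 3 h (on this read-out higher numbers stand for an effect only at larger amounts of compound and lower numbers for an effect already at smaller amounts), compound 1 gives 86 nM
Compound 2, `COc1ccc(N2CCN(S(=O)(=O)c3cccc(/C=C/C(=O)NO)c3)CC2)cc1`: in this assay compound 2 gives 1180 nM

Within the data shown here, compound 2 stands at the higher of the two numbers measured so far; the single measured step is a 14-fold higher number from compound 1 to compound 2 (1.14 log units; beyond the scatter). Compound 3, `COc1ccccc1N1CCN(S(=O)(=O)c2cccc(/C=C/C(=O)NO)c2)CC1`, keeps every atom of compound 2 and changes only where the methoxy group sits on the aryl ring: 2-methoxyphenyl in place of 4-methoxyphenyl on an amine nitrogen in a ring. Among the measured compounds shown here, no measured step moves a methoxy group around its ring; the one step in hand replaces the whole aryl group with a different ring, so it says little about a change of this kind. With nothing pointing in either direction, the expected step in this assay is none beyond the scatter, that is a 1.2-fold lower number from compound 2 to compound 3 (0.07 log units; within the scatter). Compound 3 is therefore estimated at 1000 nM in this assay, with a range from 300 nM to 3500 nM.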

Compound 3, concentration for half-maximal effect: 145 nM
Beside the measured number, compound 3's estimate is 6.9-fold (0.84 log units) above it; measured number below the stated range.
By their numbers in this assay, from the lowest: compounds 1 and 3 (each within the scatter of the next); then compound 2.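

In this assay, the place of the methoxy group matters on its own: with the same atoms, 2-methoxyphenyl in place of 4-methoxyphenyl gives a clear shift (an 8.1-fold lower number from compound 2 to compound 3 (0.91 log units; beyond the scatter)). The aryl group on the ring nitrogen therefore need not be a pyridin-2-yl to reach the low end of the numbers, since 2-methoxyphenyl and pyridin-2-yl cannot be told apart here (a 1.7-fold higher number from compound 1 to compound 3 (0.23 log units; within the scatter)). Nothing in hand gives a measured reason for this effect of position.

The compounds shown do not tell whether the methoxy group itself is needed, or whether a chlorine atom or an ethoxy group on the same ring would give a similar number. They also leave open whether the same order of compounds holds for other histone deacetylases.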